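Sulfamoylurea variations tested for sterol O-acyltransferase inhibition

This account rests on a few compounds, and the source may have more. Where it says the series, first, only, none or still open, it means among the compounds named here.

The measured compounds and their values are:

Compound 1 `CC(C)c1cccc(C(C)C)c1NC(=O)NS(=O)(=O)N(C)C`: 3900 nM
Compound 2 `C=CCN(CC=C)S(=O)(=O)NC(=O)Nc1c(C(C)C)cccc1C(C)C`: 2700 nM
Compound 3 `CC(C)c1cccc(C(C)C)c1NC(=O)NS(=O)(=O)N1CCCCC1`: 17000 nM

In an assay on liver for inhibition of sterol O-acyltransferase 1 (Rattus norvegicus), using microsomes (a lower number here means a stronger inhibitor, a higher number a weaker inhibitor), compound 3 gives the highest number of the three measured. The step of a 4.4-fold higher number from compound 1 to compound 3 (0.64 log units; beyond the scatter) and the step of a 6.3-fold higher number from compound 2 to compound 3 (0.80 log units; beyond the scatter) both show that the ring-closed piperidin-1-yl group on the sulfonyl sulfur comes with a weaker result than either open dialkylamino group.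

Compound 4 `CC(C)CN(CC(C)C)S(=O)(=O)NC(=O)Nc1c(C(C)C)cccc1C(C)C` returns to an open group: diisobutylamino in place of piperidin-1-yl on a sulfonyl sulfur. Both steps that bear on this are modest and run the other way, so a modest decrease in this assay from compound 3 to compound 4 is expected, though diisobutylamino itself has not been measured and the size is uncertain. The step is estimated as a 4.9-fold lower number from compound 3 to compound 4 (0.69 log units; beyond the scatter). Compound 4 is therefore expected to give 3500 nM, in a range from 1200 nM to 10000 nM.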

Compound 4, half-maximal inhibitory concentration: 420 nM
The estimate for compound 4 lay 8.3-fold (0.92 log units) above the measured number, and the stated range ends above it.
By their numbers in this assay, from the lowest: compound 4; then compounds 2 and 1 (each within the scatter of the next); then compound 3.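

In this assay the open groups now separate: dimethylamino and diallylamino had stayed within the scatter of each other, but diisobutylamino gives a 6.4-fold lower number from compound 2 to compound 4 (0.81 log units; beyond the scatter) and a 9.3-fold lower number from compound 1 to compound 4 (0.97 log units; beyond the scatter). Going by these compounds alone, the change from the ring also goes well beyond recovering the open-group level, with a 40-fold lower number from compound 3 to compound 4 (1.61 log units; beyond the scatter) and so the sulfonyl sulfur position proves more responsive than the earlier compounds showed. Nothing given here accounts for this gain. Going by these compounds, whether branching matters remains open, since di-n-butylamino would test an unbranched chain. Azepan-1-yl would likewise show whether a larger ring escapes the piperidin-1-yl result.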